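Hydrogen in place of fluoro on compound 1

The source may report more compounds than this note shows. Statements on the series, on what has been measured and on what is new or still open speak of the compounds shown alone.

Measured in a functional assay for agonist activity, with Homo sapiens as the target; on this read-out lower numbers stand for stronger inhibition and higher numbers for weaker inhibition:
- compound 1 `O=C(O)CCC/C=C1/C[C@H]2C[C@@H](O)[C@H](/C=N/OCc3ccc(F)cc3)[C@H]2C1`: 14000 nM
- compound 2 `O=C(O)CCC/C=C1\C[C@H]2C[C@@H](O)[C@H](/C=N/OCc3ccc(F)cc3)[C@H]2C1`: 1900 nM

Compound 1 stands highest of the two, with a 7.4-fold lower number from compound 1 to compound 2 (0.87 log units; beyond the scatter). That step goes with the fact that compounds 1 and 2 differ only in the configuration as drawn, so it says nothing about the aromatic ring.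

Compound 3 `O=C(O)CCC/C=C1/C[C@H]2C[C@@H](O)[C@H](/C=N/OCc3ccccc3)[C@H]2C1` keeps the double bond as drawn in compound 1 and changes at one place: hydrogen in place of fluoro on an aromatic carbon. This is hydrogen in place of fluoro on an aromatic carbon, para to a large group.

Among the measured compounds shown here, no measured step makes this change, and the only one, a 7.4-fold lower number from compound 1 to compound 2 (0.87 log units; beyond the scatter), is a change of configuration. With compound 1 at 14000 nM as the anchor, no step beyond the scatter is expected in this assay, and no direction is favoured. The expected step is a 1.2-fold lower number from compound 1 to compound 3 (0.07 log units; within the scatter). For compound 3 the estimated value is 12000 nM, with an expected range of 5000 nM to 30000 nM.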

Compound 3, half-maximal inhibitory concentration: 5400 nM
For compound 3 the middle estimate is 2.2-fold (0.35 log units) above the measured one; the measured number falls inside the stated range.
By their numbers in this assay, from the lowest: compound 2; then compound 3; then compound 1.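

In this assay the place on the aromatic ring para to a large group is not indifferent: hydrogen in place of fluoro gives a 2.6-fold lower number from compound 1 to compound 3 (0.41 log units; beyond the scatter) with the double bond kept as drawn in compound 1. Among the compounds shown here, the earlier pair changed configuration alone, so this is the first reading of the aromatic ring, and it shows that the fluoro is not required for the activity seen, as the unsubstituted benzyloxy compound gives the lower number. Nothing at hand gives a cause for this step.

From the compounds shown here alone, whether the same change gives a step of similar size with the double bond drawn as in compound 2 stays open. Also open, going by these compounds, is how a chloro, methoxy or nitrile group would read at this place, which would show whether hydrogen is the better choice here or fluoro is simply a poor one.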